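Crown ether esters: pyridin-3-yl gives way to phenylbutyl

The source may hold more compounds than are shown below. What is called first, only, known or untested is meant among the compounds shown, and "the series" means these compounds.

Compound 2 `O=C(OCC1COCCOCCOCCOCCOCCO1)c1cccnc1` is an ester of a crown-ether alcohol. In a functional assay on HeLa cells (Homo sapiens) for inhibition, read by sulforhodamine B assay, with a stated time of 48 h (on this read-out higher numbers stand for weaker inhibition of growth and lower numbers for stronger inhibition of growth), compound 2 gives > 100000 nM, which is a limit of the assay rather than a measured number, (the limit of > 100000 nM in this assay, at which 1 of the 2 values shown sits). Its neighbour compound 1 `O=C(CCCCCc1ccccc1)OCC1COCCOCCOCCOCCOCCO1` gives 79000 nM in this assay. Going by the values given here, the one measured step, an at least 1.2-fold higher number from compound 1 to compound 2 (0.10 log units; that floor lies within the scatter), concerns the same position as the change to compound 3 `O=C(CCCCc1ccccc1)OCC1COCCOCCOCCOCCOCCO1`: 4-phenylbutyl in place of pyridin-3-yl on a carbonyl carbon. Since 4-phenylbutyl is the near twin of 5-phenylpentyl, compound 3 is expected to fall close to compound 1, and the step of an at least 1.1-fold lower number from compound 2 to compound 3 (0.04 log units; that floor lies within the scatter) is expected to reverse the earlier weakening, though it may stay within scatter. Compound 3 is estimated at 90000 nM, ranging from 40000 nM to 200000 nM.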

Compound 3, concentration for 50% growth inhibition: 52000 nM
The estimate for compound 3 lay 1.7-fold (0.24 log units) above the measured number, and the stated range covers the measured number.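

Compound 2 carries a limit of the assay, not a number: the limit of > 100000 nM in this assay, at which 1 of the 3 values shown sits. On these data alone, putting 4-phenylbutyl in place of pyridin-3-yl gives an at least 1.9-fold lower number from compound 2 to compound 3 (0.28 log units; that floor lies within the scatter), so the real size of this change remains unknown and could be larger. Between the two phenyl-ended chains, the change gives a 1.5-fold lower number from compound 1 to compound 3 (0.18 log units; within the scatter), so 4-phenylbutyl and 5-phenylpentyl cannot be told apart here. As far as these compounds go, whether a much shorter chain, or a chain ending in an amine or a carboxylic acid, would move the number beyond the scatter remains open.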